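The source may hold more compounds than are shown below. What is called first, only, known or untested is meant among the compounds shown, and "the series" means these compounds.

- Compound 1 `Cc1ccc(C2C(C#N)=C(N)Oc3cc(C)oc(=O)c32)cc1`: 54000 nM
- Compound 2 `Cc1cc2c(c(=O)o1)C(c1ccccc1)C(C#N)=C(N)O2`: 46000 nM
- Compound 3 `COc1ccc(C2C(C#N)=C(N)Oc3cc(C)oc(=O)c32)cc1`: 57000 nM

These three compounds share one core and were tested in a functional assay on MCF7 cells (Homo sapiens) for cytotoxicity, read by MTT assay, with a stated time of 96 h; on this read-out lower numbers stand for stronger inhibition and higher numbers for weaker inhibition. There, compound 3 gives 57000 nM, which places it within the scatter of both other compounds: the series shows a 1.1-fold higher number from compound 1 to compound 3 (0.02 log units; within the scatter) and a 1.2-fold higher number from compound 2 to compound 3 (0.09 log units; within the scatter). The next compound, compound 4 `Cc1cc2c(c(=O)o1)C(c1ccc([N+](=O)[O-])cc1)C(C#N)=C(N)O2`, keeps the core of compound 3 and changes one group: nitro in place of methoxy on an aromatic carbon. This is nitro in place of methoxy on an aromatic carbon, para to a large group.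

The measured steps that bear on this change are those among hydrogen, methyl and methoxy at that place. Besides the two steps above, there is a 1.2-fold lower number from compound 1 to compound 2 (0.07 log units; within the scatter). All three are small and lie within the scatter. Among the compounds with values here, none of the measured compounds carries a nitro, however, so the data do not test that group directly, and the range must stay wide. On the evidence of these small steps, no change beyond the scatter is expected in this assay. The expected result is a 1.3-fold lower number from compound 3 to compound 4 (0.10 log units; within the scatter). For compound 4 the estimated value is 45000 nM, with an expected range from 18000 nM to 90000 nM.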

Compound 4, half-maximal inhibitory concentration: 42000 nM
Compound 4: middle estimate off by 1.1-fold (0.03 log units), on the high side, and the stated range covers the measured number.
By their numbers in this assay, from the lowest: compounds 4, 2, 1 and 3 (each within the scatter of the next).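

In this assay, nitro on an aromatic carbon, para to a large group, joins hydrogen, methyl and methoxy at this place without breaking the flat picture those three gave: the new steps are a 1.4-fold lower number from compound 3 to compound 4 (0.13 log units; within the scatter) and a 1.1-fold lower number from compound 2 to compound 4 (0.04 log units; within the scatter) and a 1.3-fold lower number from compound 1 to compound 4 (0.11 log units; within the scatter). Within the data shown here, the earlier compounds covered only hydrogen, methyl and methoxy, so compound 4 is the first to show that this place also accepts nitro, the only one of the four groups with a double bond outside aromatic rings, with no step beyond the scatter. No measurement among those shown accounts for this flat response.

On these data alone, whether an amine or a carboxylic acid at this place would move the number beyond the scatter stays open, as does the effect of a longer chain in place of the methyl on the shared core. Whether the same flat picture carries over to other cell lines also remains an open question.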